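This account rests on a few compounds, and the source may have more. Where it says the series, first, only, none or still open, it means among the compounds named here.

Measured compounds:
- compound 1, `O=C(Nc1cccc(-n2cc(-c3ccncc3)c(-c3ccc(Cl)c(O)c3)n2)c1)Nc1cccc(C(F)(F)F)c1`: 1640 nM
- compound 2, `COc1cc(-c2nn(-c3cccc(NC(=O)Nc4ccc(Cl)c(C(F)(F)F)c4)c3)cc2-c2ccncc2)ccc1Cl`: 1200 nM

Of the compounds shown here, two have been measured in a functional assay on IGROV-1 cells (Homo sapiens) for inhibition, read by sulforhodamine B assay, with a stated time of 48 h; on this read-out higher numbers stand for weaker inhibition of growth and lower numbers for stronger inhibition of growth. Compound 1 gives 1640 nM in this assay, and compound 2 gives 1200 nM. Compound 2 carries the lower of the two numbers, but the gap to compound 1 lies within the scatter of repeated measurements, so the two values cannot be told apart.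

Compound 3, `O=C(Nc1cccc(-n2cc(-c3ccncc3)c(-c3ccc(Cl)c(O)c3)n2)c1)Nc1ccc(Cl)c(C(F)(F)F)c1`, has not yet been measured. It differs from compound 2 in one place: hydrogen in place of methyl on an oxygen on an aromatic ring. Among the measured compounds shown here, no pair of measured compounds shows this same change on its own, so the size of the step has to be judged without a direct precedent. The two measured values suggest that the shared core with either a methoxy or a hydroxy group sits in the same range in this assay, though compound 1 and compound 2 also differ elsewhere.

Compound 3 is therefore expected to stay close to compound 2, with a step of a 1.2-fold higher number from compound 2 to compound 3 (0.07 log units; within the scatter) that is not expected to exceed the scatter. The estimate for compound 3 in this assay is 1400 nM, with a range from 500 nM to 4000 nM.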

Compound 3, concentration for 50% growth inhibition: 715 nM
Estimate against measurement, compound 3: 2.0-fold (0.29 log units) above; measured number inside the range.
By their numbers in this assay, from the lowest: compounds 3, 2 and 1 (each within the scatter of the next, the first and the last beyond it).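

In this assay, replacing methoxy with hydroxy in the 4-chloro-3-methoxyphenyl group gives a 1.7-fold lower number from compound 2 to compound 3 (0.22 log units; within the scatter), so on this oxygen on an aromatic ring the two groups cannot be told apart in this single pair. Among the compounds shown here, the other new step, chloro in place of hydrogen on an aromatic carbon, gives a 2.3-fold lower number from compound 1 to compound 3 (0.36 log units; beyond the scatter); this modest step is the only one among the three compounds that lies beyond the scatter, and it is the first one-place change here to separate two values. No measurement at hand bears on why either step has the size it has.

The compounds shown leave open whether an ethyl group on that oxygen, or an amine in place of the hydroxy, would stay within the scatter of compound 3 in this assay. Going by these compounds, the chloro step is also read only once, in a pair that carries hydroxy, so whether it holds in compounds carrying methoxy remains unknown.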